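Trifluoromethyl gives way to phenyl in compound 2

The source may hold more compounds than are shown below. What is called first, only, known or untested is meant among the compounds shown, and "the series" means these compounds.

In an ADME assay on L6 cells (Rattus norvegicus) for cytotoxicity (a higher number here means a weaker inhibitor, a lower number a stronger inhibitor), compound 2 `O=[N+]([O-])c1ncn(CCCNS(=O)(=O)c2ccc(C(F)(F)F)cc2)n1` gives 235000 nM, and compound 1 `O=[N+]([O-])c1nccn1CCCNS(=O)(=O)c1ccc(C(F)(F)F)cc1` gives 176000 nM. These two numbers lie within the scatter of each other, and the step that joins them is a 1.3-fold higher number from compound 1 to compound 2 (0.13 log units; within the scatter). Compound 3 `O=[N+]([O-])c1ncn(CCNS(=O)(=O)Cc2ccccc2)n1` gives no number, only a limit of > 321000 nM.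

Compound 4 `O=[N+]([O-])c1ncn(CCCNS(=O)(=O)c2ccc(-c3ccccc3)cc2)n1` differs from compound 2 in one group: phenyl in place of trifluoromethyl on an aromatic carbon. Phenyl takes the place of trifluoromethyl on an aromatic carbon, para to a large group.

Among the measured compounds shown here, the only measured step that bears on this comparison is the one from compound 1 to compound 2, and it leaves the trifluoromethyl group untouched. It shows that one exchange in this series, a 1.3-fold higher number from compound 1 to compound 2 (0.13 log units; within the scatter), stayed within the scatter. For the measured compounds named here, it does not show what replacing trifluoromethyl does, and no measured pair makes that exchange. The expectation in this assay therefore rests on weak ground and is for a modest move to a lower number, close to the scatter, rather than a large one. The estimated change is a 1.8-fold lower number from compound 2 to compound 4 (0.26 log units; within the scatter). Compound 4 is expected at 130000 nM, with an estimated range from 45000 nM to 300000 nM.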

Compound 4, half-maximal inhibitory concentration: 50000 nM
Compound 4: middle estimate off by 2.6-fold (0.41 log units), on the high side; measured number inside the range.
By their numbers in this assay, from the lowest: compound 4; then compounds 1 and 2 (each within the scatter of the next). At a limit, above all of these: compound 3.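

Among the compounds shown here, the exchange of trifluoromethyl for phenyl on this aromatic carbon, para to a large group, gives a 4.7-fold lower number from compound 2 to compound 4 (0.67 log units; beyond the scatter) in this assay, and this is the first step to pass beyond the scatter. The earlier exchange at the other end of the chain, a 1.3-fold higher number from compound 1 to compound 2 (0.13 log units; within the scatter), stayed within the scatter, so this aromatic carbon is the one place shown where a single change clearly moves the number, though the size of that move is only modest. No measurement given here speaks to why phenyl and trifluoromethyl differ in this way.

As far as these compounds go, a single pair defines this change, so it remains open whether an amine, a carboxylic acid or a methoxy group on the same aromatic carbon would also lead to a lower number, or whether the added ring of phenyl is needed. From the compounds shown here alone, it is equally open whether phenyl would give a step of similar size with 2-nitro-1H-imidazol-1-yl in place of 3-nitro-1H-1,2,4-triazol-1-yl, or with a longer chain.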